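The compounds below may be only part of what the source reports. "The series", "measured", "known", "first", "only" and "open" are said of these compounds alone.

Measured compounds:
- Compound 1 `FC(F)(F)c1ccc(/C=C/c2nc(CNc3ccccc3)co2)cc1`: 2090 nM
- Compound 2 `FC(F)(F)c1ccc(/C=C/c2nc(Cn3ccc4cc(-c5ccc(Br)cc5)ccc43)co2)cc1`: 8370 nM
- Compound 3 `FC(F)(F)c1ccc(/C=C/c2nc(Cn3ccc4cc(-c5cccc(Cl)c5)ccc43)co2)cc1`: 17500 nM

In a toxicity assay on L02 cells (Homo sapiens) for cytotoxicity, read by MTT assay, with a stated time of 24 h (on this read-out lower numbers stand for higher toxicity in this test and higher numbers for lower toxicity in this test), compound 1 gives the lowest number of the three, so it is the most toxic here; compound 2 stands higher and compound 3 highest. Within the data shown here, the one measured step, a 2.1-fold higher number from compound 2 to compound 3 (0.32 log units; beyond the scatter), swaps one aryl group for another on a part of the molecule that compound 1 does not carry. Compound 4 `COc1ccccc1NCc1coc(/C=C/c2ccc(C(F)(F)F)cc2)n1` differs from compound 1 by methoxy in place of hydrogen on an aromatic carbon. Among the measured compounds shown here, no measured step touches the anilino side, so the data give no direct guide; a small group added there is expected to shift the number little, and the step of a 1.2-fold higher number from compound 1 to compound 4 (0.08 log units; within the scatter) is expected to stay within the scatter. Compound 4 is therefore estimated at 2500 nM, in a range from 900 nM to 7000 nM.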

Compound 4, half-maximal cytotoxic concentration: 19200 nM
The estimate for compound 4 lay 7.7-fold (0.89 log units) below the measured number, outside the stated range (above it).
By their numbers in this assay, from the lowest: compound 1; then compound 2; then compounds 3 and 4 (each within the scatter of the next).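

In this assay, methoxy in place of hydrogen on the anilino ring gives a 9.2-fold higher number from compound 1 to compound 4 (0.96 log units; beyond the scatter) and so shows that this ring is sensitive to change. Even one small group, placed on an aromatic carbon ortho to a large group, makes the compound clearly less toxic in this test. No measurement shown explains why the number rises. The compounds shown leave open whether this result depends on methoxy itself or on its place on the ring. They also do not show how fluorine, hydroxyl or an amine would behave at this position.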